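Swapping One Aryl Group on a Potent Compound

A few compounds are considered here, and "the series" means these few. Any claim that something is new, unique, unknown or untested is made for them only; others in the source may bear on it.

Compound 1 `COc1ccc(OC)c(/C=C/C(=O)/C=C(O)/C=C/c2cc(OC)ccc2OC)c1`: 16300 nM
Compound 2 `COc1cccc(/C=C/C(=O)C(=Cc2ccc(F)cc2)C(=O)/C=C/c2cccc(OC)c2OC)c1OC`: 340 nM
Compound 3 `COc1ccc(C=C(C(=O)/C=C/c2cccc(OC)c2OC)C(=O)/C=C/c2cccc(OC)c2OC)cc1OC`: 170 nM

In a functional assay on A549 cells (Homo sapiens) for antiproliferative activity, read by sulforhodamine B assay, with a stated time of 48 h (on this read-out higher numbers stand for weaker inhibition and lower numbers for stronger inhibition), compound 3 gives 170 nM. It sits at the low end of the numbers together with compound 2, since the two are separated by a 2.0-fold lower number from compound 2 to compound 3 (0.30 log units; within the scatter). Compound 1 lies far higher, at 16300 nM.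

The next structure is compound 4 `COc1cccc(/C=C/C(=O)C(=Cc2ccc(O)c(F)c2)C(=O)/C=C/c2cccc(OC)c2OC)c1OC`. It carries 3-fluoro-4-hydroxyphenyl in place of the 3,4-dimethoxyphenyl of compound 3, on a double-bonded chain carbon bound to a double-bonded chain carbon: 3-fluoro-4-hydroxyphenyl in place of 3,4-dimethoxyphenyl on a double-bonded chain carbon bound to a double-bonded chain carbon.

Going by the values given here, only one measured step touches this place: a 2.0-fold lower number from compound 2 to compound 3 (0.30 log units; within the scatter). That exchange of 4-fluorophenyl for 3,4-dimethoxyphenyl left the number within the scatter, which suggests some tolerance at this place, though one step is thin evidence. Among the compounds with values here, no measured compound has a hydroxyl group on this ring, so the new group remains untested, and the range must stay wide. A change beyond the scatter is therefore not expected. In this assay the estimated step is a 1.5-fold higher number from compound 3 to compound 4 (0.17 log units; within the scatter). For compound 4 the expected value is 250 nM, with an estimated range of 90 nM to 700 nM.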

Compound 4, half-maximal inhibitory concentration: 200 nM
Compound 4: middle estimate off by 1.3-fold (0.10 log units), on the high side; the range from low to high includes it.
By their numbers in this assay, from the lowest: compounds 3, 4 and 2 (each within the scatter of the next); then compound 1.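

In this assay, the step to the new group is small from either earlier compound: a 1.2-fold higher number from compound 3 to compound 4 (0.07 log units; within the scatter) and a 1.7-fold lower number from compound 2 to compound 4 (0.23 log units; within the scatter). The earlier compounds shown here showed only that 4-fluorophenyl and 3,4-dimethoxyphenyl could be exchanged within the scatter, while compounds 2, 3 and 4 now show the same for three different aromatic groups at this place, one of them carrying a hydroxyl group and the hydrogen-bond donor counted with it. Nothing measured here explains why the number stays put when the ring's groups are exchanged in this way.

All three groups are still six-membered aromatic rings of carbon, so the tolerance is shown only for such rings, and a ring bearing an amine or a carboxylic acid, or a saturated cyclohexyl group in place of the aromatic ring, remains an open case. Compound 4 also brings in its fluorine and hydroxyl group together, so a phenyl ring bearing the hydroxyl group without the fluorine would be needed to tell what each contributes on its own.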